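The source may report more compounds than this note shows. Statements on the series, on what has been measured and on what is new or still open speak of the compounds shown alone.

In an assay on isolated protein for inhibition of protein kinase C epsilon type (Homo sapiens), read by coupled enzyme assay (a higher number here means a weaker inhibitor, a lower number a stronger inhibitor), compound 1 `N#CC1(c2cc(CCO)cc(-c3ccnc4[nH]nc(C(F)(F)F)c34)c2)CC1` gives 25 nM, and compound 2 `COCCc1cc(-c2ccnc3[nH]nc(C(F)(F)F)c23)cc(C2(C#N)CC2)c1` gives 145 nM. Within the data shown here, compound 2 therefore stands at the weaker end of the two numbers measured so far, with the step from compound 1 being a 5.8-fold higher number from compound 1 to compound 2 (0.76 log units; beyond the scatter), brought about by methyl in place of hydrogen on an oxygen on a saturated carbon. Compound 3 `CCc1cc(-c2ccnc3[nH]nc(C(F)(F)F)c23)cc(C2(C#N)CC2)c1` takes the change one stage further: hydrogen in place of methoxy on a saturated chain carbon, two bonds along the chain from an aromatic carbon. Among the measured compounds shown here, the one measured step bears on this only indirectly, since it capped the oxygen rather than removing it; it shows that the free hydroxyl of compound 1 is worth keeping, but gives no direct reading on what the 2-methoxyethyl chain contributes once it becomes ethyl. He expects the number in this assay to stay near that of compound 2 or drift a little higher, an expected step of a 1.4-fold higher number from compound 2 to compound 3 (0.14 log units; within the scatter). For compound 3 he estimates 200 nM, within a range of 70 nM to 600 nM.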

Compound 3, inhibition constant: 78 nM
For compound 3 the middle estimate is 2.6-fold (0.41 log units) above the measured one; the measured number falls inside the stated range.
By their numbers in this assay, from the lowest: compound 1; then compounds 3 and 2 (each within the scatter of the next).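

In this assay, ethyl in place of 2-methoxyethyl gives a 1.9-fold lower number from compound 2 to compound 3 (0.27 log units; within the scatter), so these two chains are not told apart. Hydrogen in place of hydroxy gives a 3.1-fold higher number from compound 1 to compound 3 (0.49 log units; beyond the scatter), which means that compound 1 stands apart from both compound 2 and compound 3 as the strongest inhibitor of the three, and that an oxygen on the chain is not enough on its own: compound 2 keeps one, capped with methyl, yet does not separate from compound 3, which has none. Nothing shown explains why the free hydroxy counts for so much.

The compounds shown leave open whether an amine or a carboxylic acid in place of the hydroxy could match compound 1 in this assay. They also leave open whether a longer chain carrying the hydroxy would do so.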